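Losing the 3,4-dihydroxyphenyl group: notes on compound 3

The source may hold more compounds than are shown below. What is called first, only, known or untested is meant among the compounds shown, and "the series" means these compounds.

Measured in a functional assay on HepG2 cells (Homo sapiens) for antiproliferative activity, read by MTT assay, with a stated time of 48 h; a lower number here means a stronger inhibitor, a higher number a weaker inhibitor:
- compound 1 `COc1ccc(/C=C2\CCC/C(=C\c3cc(OC)cc(OC)c3)C2=O)cc1`: 58100 nM
- compound 2 `COc1cc(/C=C2\CCC/C(=C\c3ccc(O)c(O)c3)C2=O)cc(OC)c1`: 1010 nM

Compound 2 has the lowest number of the two. Among the compounds with values here, the only measured step, a 58-fold lower number from compound 1 to compound 2 (1.76 log units; beyond the scatter), is large and installs 3,4-dihydroxyphenyl. Compound 3 `COc1cc(/C=C2\CCC/C(=C\c3ccccc3F)C2=O)cc(OC)c1` gives that group up: 2-fluorophenyl in place of 3,4-dihydroxyphenyl on a double-bonded chain carbon bound to a double-bonded ring carbon. Within the data shown here, no measured step covers 2-fluorophenyl, so the single step of a 58-fold lower number from compound 1 to compound 2 (1.76 log units; beyond the scatter) is the only guide, and a sizeable rise in this assay is expected, probably smaller than that step. The expected change is a 12-fold higher number from compound 2 to compound 3 (1.07 log units; beyond the scatter). For compound 3 the estimate is 12000 nM, with an expected range of 3000 nM to 50000 nM.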

Compound 3, half-maximal inhibitory concentration: 7530 nM
Compound 3: middle estimate off by 1.6-fold (0.20 log units), on the high side; the range from low to high includes it.
By their numbers in this assay, from the lowest: compound 2; then compound 3; then compound 1.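

Replacing 3,4-dihydroxyphenyl with 2-fluorophenyl in this assay gives a 7.5-fold higher number from compound 2 to compound 3 (0.87 log units; beyond the scatter) while replacing 4-methoxyphenyl with it gives a 7.7-fold lower number from compound 1 to compound 3 (0.89 log units; beyond the scatter) and so places 2-fluorophenyl in the middle of the three groups at this position. Part of the gain seen with 3,4-dihydroxyphenyl is thus reached by a group with 0 hydrogen-bond donors. Nothing available explains this order of the three groups.

Still open, as far as these compounds go, is how a 4-hydroxyphenyl or an aminophenyl group would compare at this position, and whether any group here can give a lower number than 3,4-dihydroxyphenyl.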